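A few compounds are considered here, and "the series" means these few. Any claim that something is new, unique, unknown or untested is made for them only; others in the source may bear on it.

Measured in a functional assay on MCF7 cells (Homo sapiens) for antiproliferative activity; a higher number here means a weaker inhibitor, a lower number a stronger inhibitor:
Compound 1 `Cc1cc(-c2nc3ccccc3s2)ccc1N`: < 1 nM
Compound 2 `Nc1ccc(-c2nc3ccccc3s2)cc1Cl`: < 1 nM
Compound 3 `CC(=O)Nc1ccc(-c2nc3ccccc3s2)cc1C`: > 10000 nM

Compound 3 stands at > 10000 nM, which is a limit and not a number. The other two compounds are described by the limit of < 1 nM in this assay, at which 2 of the 3 values shown sit.

Compound 4 `CC(=O)Nc1ccc(-c2nc3ccccc3s2)cc1Cl` comes from compound 3 by a single change: chloro in place of methyl on an aromatic carbon. It is chloro in place of methyl on an aromatic carbon, ortho to an acetamido group.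

Within the data shown here, two measured steps bear on this change. Going by these compounds, the same swap without the acetyl group appears as a step that the two limits leave unreadable from compound 1 to compound 2, so its size remains unknown. Adding the acetyl group gave an at least 10000-fold higher number from compound 1 to compound 3 (4.00 log units; beyond the scatter), and compound 4 keeps that acetyl group. Compound 4 is therefore expected to remain close to compound 3 in this assay, with no step beyond the scatter as the likeliest outcome, although the unread swap leaves a lower number possible. The expected step is a number no higher from compound 3 to compound 4 (the limit leaves the size open). The estimate for compound 4 is 10000 nM, with an expected range from 30 nM to 30000 nM.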

Compound 4, half-maximal inhibitory concentration: > 10 nM
Compound 4 gave a limit, no number (the forecaster's own chance of this, stated with the estimate: 60%); the middle value lies beyond the limit too.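

In this assay compound 4 gives > 10 nM, which is a limit and not a number, so the swap of methyl for chloro cannot be read here, just as it could not be read without the acetyl group. What is new is that placing an acetyl group on the nitrogen also raises the number when chloro rather than methyl sits on the aromatic carbon, with an at least 10-fold higher number from compound 2 to compound 4 (1.00 log units; beyond the scatter). The acetyl step therefore now stands on two cores, both times beyond the scatter, though its two sizes cannot be compared: the same change on two cores in this assay, an at least 10000-fold higher number (4.00 log units; beyond the scatter) from compound 1 to compound 3 and an at least 10-fold higher number (1.00 log units; beyond the scatter) from compound 2 to compound 4; the limit leaves it open whether they differ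

The compounds shown leave open where the true value of compound 4 lies, and so whether chloro and methyl differ once the nitrogen carries an acetyl group. They also leave open how a formyl group or a longer acyl chain on that nitrogen would read in this assay.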